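Ring swap on the shared core: compound 3 next

The compounds below may be only part of what the source reports. "The series", "measured", "known", "first", "only" and "open" are said of these compounds alone.

Going by the values given here, in a physicochemical assay for solubility, in phosphate buffer, at pH 7.4 (a lower number here means a less soluble compound, a higher number a more soluble compound), compound 1 (`CC(=O)N[C@@H]1CCC[C@H](C(=O)Nc2cc(-c3cnn4c3CCCC4)c(Cl)cn2)C1`) gives 310000 nM and compound 2 (`CC(=O)N[C@@H]1CCC[C@H](C(=O)Nc2cc(-c3nnn4ccccc34)c(Cl)cn2)C1`) gives 530000 nM as the only two numbers so far. The two lie within the scatter of each other, so compound 2 stands level with compound 1. Compound 3 (`CC(=O)N[C@@H]1CCC[C@H](C(=O)Nc2cc(-c3cnn4c3CCCCC4)c(Cl)cn2)C1`) differs from compound 2 by a group of 10 heavy atoms (8 carbon, 2 nitrogen; one five-membered aromatic ring with 2 hetero atoms, one seven-membered non-aromatic ring with 1 hetero atom) in place of a group of 9 heavy atoms (6 carbon, 3 nitrogen; one five-membered aromatic ring with 3 hetero atoms, one six-membered aromatic ring with 1 hetero atom), on an aromatic carbon and is not yet measured. Among the compounds with values here, one measured step bears on this change: a 1.7-fold higher number from compound 1 to compound 2 (0.23 log units; within the scatter) stays within the scatter. Within the data shown here, it is the only measured exchange at this position, and the group of compound 1 shares with the entering group a five-membered aromatic ring with 2 hetero atoms and a non-aromatic ring. No step beyond the scatter is therefore expected in this assay and the estimate is a step of a 1.8-fold lower number from compound 2 to compound 3 (0.25 log units; within the scatter) as a small one. For compound 3 the estimated value is 300000 nM with an expected range from 130000 nM to 650000 nM as the working figures.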

Compound 3, solubility: 104000 nM
The estimate for compound 3 lay 2.9-fold (0.46 log units) above the measured number; measured number outside the range, below it.
By their numbers in this assay, from the lowest: compound 3; then compounds 1 and 2 (each within the scatter of the next).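

In this assay, going by these compounds alone, the group with the seven-membered non-aromatic ring gives the first exchange at this position that lies beyond the scatter, with a 5.1-fold lower number from compound 2 to compound 3 (0.71 log units; beyond the scatter) as the step against the group with the six-membered aromatic ring. The same entering group also stands apart from the closer group with the six-membered non-aromatic ring, with a 3.0-fold lower number from compound 1 to compound 3 (0.47 log units; beyond the scatter) as the step, so the size of that non-aromatic ring alone separates two compounds in this assay. Nothing available explains this shift at the position on the ring opposite the ring nitrogen.

Two ring sizes cannot show whether the number keeps following the size of the non-aromatic ring. From the compounds shown here alone, how an amine or a carboxylic acid on the seven-membered non-aromatic ring would read in this assay also remains open.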